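Moving a Methyl Group Around an Aromatic Ring

The source may hold more compounds than are shown below. What is called first, only, known or untested is meant among the compounds shown, and "the series" means these compounds.

Measured so far:
compound 1, `CC1=NN(c2ccc(C)cc2)C(=O)C12C=CC(=O)C=C2c1cccc(C)c1`, gives 22500 nM in a functional assay on A549 cells (Homo sapiens) for antiproliferative activity, read by CCK-8 assay, with a stated time of 72 h; on this read-out lower numbers stand for stronger inhibition and higher numbers for weaker inhibition;
compound 2, `CC1=NN(c2ccc(C)cc2)C(=O)C12C=CC(=O)C=C2c1ccc(C)cc1`, gives 37000 nM in this assay;
compound 3, `CC1=NN(c2ccc(Cl)cc2)C(=O)C12C=CC(=O)C=C2c1ccc(C)cc1`, gives 33400 nM in this assay.

All three numbers lie close together. Compound 3 differs from compound 2 only by chloro in place of methyl on an aromatic carbon, and this gives a 1.1-fold lower number from compound 2 to compound 3 (0.04 log units; within the scatter). Compound 1 differs from compound 2 by 3-methylphenyl in place of 4-methylphenyl on a double-bonded ring carbon, which gives a 1.6-fold lower number from compound 2 to compound 1 (0.22 log units; within the scatter). Neither step is large enough to stand out from the noise of repeated testing.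

Compound 4, `CC1=NN(c2ccc(Cl)cc2)C(=O)C12C=CC(=O)C=C2c1cccc(C)c1`, has not yet been measured. It differs from compound 3 by 3-methylphenyl in place of 4-methylphenyl on a double-bonded ring carbon. This is the same change that separates compound 1 from compound 2, made at the same place, but on the core of compound 3 rather than the core of compound 2; the two cores differ by chloro in place of methyl on an aromatic carbon.

Because a 1.6-fold lower number from compound 2 to compound 1 (0.22 log units; within the scatter) stayed within the scatter, the same change on compound 3 is expected to give a step of similar size, and the expected step from compound 3 to compound 4 in this assay is a 1.6-fold lower number from compound 3 to compound 4 (0.20 log units; within the scatter). On that basis compound 4 is estimated to give 21000 nM in this assay, with a likely range from 10000 nM to 45000 nM. Since all the known numbers are weak, compound 4 is expected to remain a weak inhibitor.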

Compound 4, half-maximal inhibitory concentration: 38400 nM
Beside the measured number, compound 4's estimate is 1.8-fold (0.26 log units) below it, and the stated range covers the measured number.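

In this assay, 3-methylphenyl in place of 4-methylphenyl on the chloro-bearing core gives a 1.1-fold higher number from compound 3 to compound 4 (0.06 log units; within the scatter), and set beside the same change on the methyl-bearing core, it shows no gap that stands clear of the noise: the same change on two cores in this assay, a 1.6-fold lower number (0.22 log units; within the scatter) from compound 2 to compound 1 and a 1.1-fold higher number (0.06 log units; within the scatter) from compound 3 to compound 4, 1.9-fold (0.28 log units) apart, within the scatter of two such steps. Chloro in place of methyl, made here on the core that carries 3-methylphenyl, gives a 1.7-fold higher number from compound 1 to compound 4 (0.23 log units; within the scatter), and it likewise shows no such gap when compared with the same change on the core that carries 4-methylphenyl: the same change on two cores in this assay, a 1.1-fold lower number (0.04 log units; within the scatter) from compound 2 to compound 3 and a 1.7-fold higher number (0.23 log units; within the scatter) from compound 1 to compound 4, 1.9-fold (0.28 log units) apart, within the scatter of two such steps. Since every one of these steps lies within the scatter, the four compounds show that neither change has a detectable effect on either core, but they do not show that a real effect carries over from one core to another, as there is no clear effect here to follow.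

Going by these compounds, it remains open whether a different group at these places, such as an amine, a carboxylic acid or a longer chain in place of the methyl, would move the number beyond the scatter. On these data alone, it also remains open whether a step of that size would keep its size when made on a second core.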